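Trimming the ester side chain on the chloropurine series

This account rests on a few compounds, and the source may have more. Where it says the series, first, only, none or still open, it means among the compounds named here.

Of the compounds shown here, two have been measured in a functional assay on the whole organism (Tail, strain ICR) with Mus musculus as the target, in the tail flick test, with a stated time of 90 min, at a dose of 25 umol/kg by the oral route; on this read-out higher numbers stand for a stronger effect at the one dose given and lower numbers for a weaker effect. Compound 1 `CSCC[C@H](NC(=O)CN(c1nc(Cl)nc2[nH]cnc12)C1CC1)C(=O)OCc1ccccc1` gives 44.6% in this assay, and compound 2 `CC(C)[C@H](NC(=O)CN(c1ncnc2c1ncn2C1CCCCO1)C1CC1)C(=O)OCc1ccccc1` gives 30.1% in this assay. Of the two numbers, that of compound 1 is the higher, and the gap to compound 2 lies beyond the usual scatter of the measurement.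

Compound 3 `C[C@H](NC(=O)CN(c1nc(Cl)nc2[nH]cnc12)C1CC1)C(=O)OCc1ccccc1` keeps the core and the ester of compound 1 and changes only the side chain: hydrogen in place of (methylsulfanyl)methyl on a saturated chain carbon, two bonds along the chain from an amide-type nitrogen and a carbonyl carbon. Going by the values given here, no measured pair shows this change, so its effect in this assay is open. Since the whole of the rest of compound 1 is kept, the step is expected to be modest and, if anything, downward. The step from compound 1 to compound 3 is estimated as a number 9.6 percentage points lower from compound 1 to compound 3 (within the scatter). Compound 3 is thus expected to give about 35% in this assay, within a range from 15% to 55%.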

Compound 3, a percentage reported as activity, at one dose (the size of the read-out at that dose, not a potency): 44.2%
Estimate against measurement, compound 3: 9.2 percentage points below, and the stated range covers the measured number.
By their numbers in this assay, from the lowest: compound 2; then compounds 3 and 1 (each within the scatter of the next).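

In this assay, hydrogen in place of (methylsulfanyl)methyl on a saturated chain carbon, two bonds along the chain from an amide-type nitrogen and a carbonyl carbon, gives a number 0.4 percentage points lower from compound 1 to compound 3 (within the scatter) at the one dose used. With the core and the ester of compound 1 kept, the (methylsulfanyl)methyl group is therefore not needed to hold the read-out at this dose, something that compound 1 and compound 2, which differ in more than one place, could not show. Nothing at hand explains this outcome.

Going by these compounds, whether a carboxylic acid, an amine or a longer chain at this carbon would keep the read-out remains open. So does whether the same change would read alike on the core of compound 2, or at other doses.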